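Swapping the carbamate end of compound 2 for a benzylic urea

A few compounds are considered here, and "the series" means these few. Any claim that something is new, unique, unknown or untested is made for them only; others in the source may bear on it.

Compound 2 `NS(=O)(=O)NCCCC[C@H](NC(=O)OCc1cccnc1)C(=O)Nc1nc(-c2ccccc2)cs1` is measured in an assay for inhibition of protein deacetylase HDAC6 (Homo sapiens) (a higher number here means a weaker inhibitor, a lower number a stronger inhibitor), at 600 nM, the higher of the two numbers recorded so far. Going by the values given here, compound 1 `NS(=O)(=O)NCCCC[C@H](NC(=O)OCc1cccc(Cl)c1)C(=O)Nc1nc(-c2ccccc2)cs1` gives 280 nM in this assay, and the only step recorded so far, a 2.1-fold higher number from compound 1 to compound 2 (0.33 log units; beyond the scatter), comes from the change of the aromatic ring at the end of that chain. Compound 3 `NS(=O)(=O)NCCCC[C@H](NC(=O)NCc1ccc(F)cc1)C(=O)Nc1nc(-c2ccccc2)cs1` differs from compound 2 by (4-fluorobenzyl)amino in place of (pyridin-3-yl)methoxy on a carbonyl carbon; cut one bond further out, this reads as ((pyridin-3-yl)methoxy)carbonyl to (4-fluorobenzyl)carbamoyl. Among the compounds with values here, no measured step covers this exact exchange, so the expectation rests only on the modest size of the one step seen when the aromatic ring on this chain was altered. For compound 3 a step of about a 1.4-fold lower number from compound 2 to compound 3 (0.15 log units; within the scatter) is expected, with little confidence in direction. Compound 3 is therefore estimated at 420 nM in this assay, within a range of 150 nM to 1200 nM.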

Compound 3, half-maximal inhibitory concentration: 370 nM
The estimate for compound 3 lay 1.1-fold (0.06 log units) above the measured number, within the range that was stated.
By their numbers in this assay, from the lowest: compounds 1, 3 and 2 (each within the scatter of the next, the first and the last beyond it).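

In this assay the carbonyl carbon accepts (4-fluorobenzyl)amino in place of (pyridin-3-yl)methoxy (a 1.6-fold lower number from compound 2 to compound 3 (0.21 log units; within the scatter)) and in place of (3-chlorobenzyl)oxy (a 1.3-fold higher number from compound 1 to compound 3 (0.12 log units; within the scatter)). Neither step goes beyond the scatter, so among these three compounds, a carbamate end can give way to a benzylic urea end, which brings a hydrogen-bond donor, with no clear shift in the number, although compound 1 and compound 2 do differ beyond the scatter. No measurement here accounts for this result.

The linking nitrogen and the 4-fluorophenyl ring enter together, so the contribution of each alone cannot be read. On these data alone, how a (2-phenylethyl)amino group or a morpholine on this carbonyl carbon would behave also remains open.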